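Notes on compound 4: butylsulfanyl in place of propoxy

The source may report more compounds than this note shows. Statements on the series, on what has been measured and on what is new or still open speak of the compounds shown alone.

The three measured compounds share one core and differ only in the group on the aromatic carbon next to the ring nitrogen. Compound 1 `CCC1CCN(c2nc(C(C)(C)C)ccc2CNC(=O)C(C)c2ccc(NS(C)(=O)=O)c(F)c2)CC1` carries 4-ethylpiperidin-1-yl there, and in an assay on cells for antagonist activity at transient receptor potential cation channel subfamily V member 1 (Homo sapiens), read by FLIPR and calcium flux, with a stated time of 6 min (a higher number here means a weaker inhibitor, a lower number a stronger inhibitor), compound 1 gives 0.1 nM. Compound 2 `CCCOc1nc(C(C)(C)C)ccc1CNC(=O)C(C)c1ccc(NS(C)(=O)=O)c(F)c1` carries propoxy; in this assay compound 2 gives 1.7 nM, the highest of the three numbers, with the step of a 17-fold higher number from compound 1 to compound 2 (1.23 log units; beyond the scatter) setting it apart from compound 1. Compound 3 `CC(C(=O)NCc1ccc(C(C)(C)C)nc1OC1CCCC1)c1ccc(NS(C)(=O)=O)c(F)c1` carries cyclopentyloxy and in this assay compound 3 gives 1.5 nM; the step of a 15-fold higher number from compound 1 to compound 3 (1.18 log units; beyond the scatter) is of the same kind, while the step of a 1.1-fold lower number from compound 2 to compound 3 (0.05 log units; within the scatter) shows that changing the chain on the ring oxygen leaves the number where it is.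

Compound 4 `CCCCSc1nc(C(C)(C)C)ccc1CNC(=O)C(C)c1ccc(NS(C)(=O)=O)c(F)c1` differs from compound 2 in one place: butylsulfanyl in place of propoxy on an aromatic carbon. Going by the values given here, no measured step exchanges the oxygen for sulfur, so the only direct guide is the step from compound 2 to compound 3, which stayed within the scatter when the chain on the oxygen was enlarged; the two large steps concern the loss of the nitrogen-linked ring and do not bear on this change. The expected step is therefore small, a 1.5-fold higher number from compound 2 to compound 4 (0.17 log units; within the scatter). Compound 4 is estimated at 2.5 nM, with a range from 0.8 nM to 8 nM.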

Compound 4, inhibition constant: 3.2 nM
Estimate against measurement, compound 4: 1.3-fold (0.11 log units) below; measured number inside the range.
By their numbers in this assay, from the lowest: compound 1; then compounds 3, 2 and 4 (each within the scatter of the next, the first and the last beyond it).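

Exchanging propoxy for butylsulfanyl gives a 1.9-fold higher number from compound 2 to compound 4 (0.27 log units; within the scatter) in this assay, so a sulfur-linked chain is tolerated at this position, although linking atom and chain length change together and this single pair cannot separate them. Against cyclopentyloxy the picture is slightly different: a 2.1-fold higher number from compound 3 to compound 4 (0.33 log units; beyond the scatter) is a modest step, the first among the groups lacking the 4-ethylpiperidin-1-yl to lie beyond the scatter, while compound 2 stays within the scatter of both compound 3 and compound 4. The step of a 32-fold higher number from compound 1 to compound 4 (1.51 log units; beyond the scatter) shows that the sulfur-linked group, like the two oxygen-linked ones, leaves a large gap to compound 1, which remains the strongest inhibitor of the four.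

Butoxy and propylsulfanyl would separate the effect of the linking atom from that of the chain, and a secondary amine such as propylamino or an unsubstituted piperidin-1-yl would test whether a nitrogen link alone closes the gap to compound 1. No available measurement accounts for the size of any of these steps.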